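A few compounds are considered here, and "the series" means these few. Any claim that something is new, unique, unknown or untested is made for them only; others in the source may bear on it.

The measured compounds are:

compound 1, `CC(C)c1ccccc1OS(=O)(=O)c1ccc(NC(=O)CCCl)cc1`, 14000 nM;
compound 2, `O=C(CCCl)Nc1ccc(S(=O)(=O)Oc2ccccc2I)cc1`, 12000 nM;
compound 3, `CCCNC(=O)Nc1ccc(S(=O)(=O)Oc2ccccc2C(C)C)cc1`, 5100 nM.

In a functional assay on M21 cells (Homo sapiens) for antiproliferative activity, read by sulforhodamine B assay, with a stated time of 48 h (a higher number here means a weaker inhibitor, a lower number a stronger inhibitor), compound 2 holds the second highest of the three numbers. Its nearest neighbour is compound 1, and the step of a 1.2-fold lower number from compound 1 to compound 2 (0.07 log units; within the scatter) shows that the two cannot be told apart; compound 3 stands further off, its value being lower than that of compound 2 by an amount that exceeds the usual scatter.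

Compound 4, `O=C(NCC1CCCC1)Nc1ccc(S(=O)(=O)Oc2ccccc2I)cc1`, differs from compound 2 in one place: (cyclopentylmethyl)amino in place of 2-chloroethyl on a carbonyl carbon. The closest measured precedent is the step of a 2.7-fold lower number from compound 1 to compound 3 (0.44 log units; beyond the scatter), in which the same 2-chloroethyl group on the carbonyl carbon gave way to an amino group, there propylamino, on the isopropyl-bearing core. Since the step of a 1.2-fold lower number from compound 1 to compound 2 (0.07 log units; within the scatter) indicates that the iodo and isopropyl cores behave alike in this assay, that precedent is expected to carry over to compound 2. Within the data shown here, the (cyclopentylmethyl)amino group is larger than propylamino, and no measured compound shows what that added size does, so the expectation rests on the propylamino precedent alone. A modest lowering of the number is therefore expected, as a 2.5-fold lower number from compound 2 to compound 4 (0.40 log units; beyond the scatter). Compound 4 is estimated at 4800 nM, within a range from 2000 nM to 12000 nM.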

Compound 4, half-maximal inhibitory concentration: 7600 nM
Estimate against measurement, compound 4: 1.6-fold (0.20 log units) below; the measured number falls inside the stated range.
By their numbers in this assay, from the lowest: compounds 3, 4, 2 and 1 (each within the scatter of the next, the first and the last beyond it).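

On the core of compound 2, placing (cyclopentylmethyl)amino on the carbonyl carbon instead of 2-chloroethyl gives a 1.6-fold lower number from compound 2 to compound 4 (0.20 log units; within the scatter) in this assay, so the two compounds cannot be told apart. Among these compounds, the position therefore accepts an amino group carrying a five-membered carbon ring in place of the chlorine-bearing chain with no change that can be read, whereas the earlier change from 2-chloroethyl to propylamino, a 2.7-fold lower number from compound 1 to compound 3 (0.44 log units; beyond the scatter), was the only change at this position to go beyond the scatter, so the lowering seen there is not general to every such replacement. Nothing given here accounts for this difference between the two changes.

Those two changes differ in both the amino group and the rest of the molecule, so the compounds shown leave open whether the entering group or the core separates them, a question that propylamino on the core of compound 2, or (cyclopentylmethyl)amino on the core of compound 1, would address. They also leave open how this position responds to a longer chain such as hexylamino, or to a ring set directly on the nitrogen, as in cyclopentylamino.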